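Chain Extension in a Cytotoxicity Series

The compounds below may be only part of what the source reports. "The series", "measured", "known", "first", "only" and "open" are said of these compounds alone.

Four compounds from one series are considered. Compound 1 `CCCCCCCCCC/C=C/c1ccc(CO[C@@H]2CN[C@@H](CO)C2)cc1` and compound 2 `CCCCCCCCCCCC/C=C/c1ccc(CO[C@@H]2CN[C@@H](CO)C2)cc1` share one core, while compound 3 `CCCCCCCCCCc1ccc(CO[C@H]2CN[C@H](CO)C2)cc1` and compound 4 `CCCCCCCCCCCCc1ccc(CO[C@H]2CN[C@H](CO)C2)cc1` share another; the difference between the two cores is not broken down here. In a functional assay on FL5.12 cells (Mus musculus) for cytotoxicity, read by flow cytometry, with a stated time of 48 h (a higher number here means a weaker inhibitor, a lower number a stronger inhibitor), compound 1 gives 2800 nM, compound 2 gives 5100 nM, and compound 3 gives 3600 nM. Compound 2 carries ethyl in place of hydrogen on a saturated chain carbon, ten or more bonds along the chain from a double-bonded chain carbon, and that change produced a 1.8-fold higher number from compound 1 to compound 2 (0.26 log units; within the scatter). Compound 4 carries ethyl in place of hydrogen on a saturated chain carbon, ten or more bonds along the chain from an aromatic carbon. The two changes are of the same kind, not the same: in the first the place on the chain is reckoned from a double-bonded chain carbon, in the second from an aromatic carbon. The earlier step stayed within the scatter, and a step of like size is expected here. The step from compound 3 to compound 4 is expected to be a 1.5-fold higher number from compound 3 to compound 4 (0.18 log units; within the scatter). Compound 4 is therefore estimated at 5500 nM, with a range from 2500 nM to 12000 nM.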

Compound 4, half-maximal inhibitory concentration: 3900 nM
For compound 4 the middle estimate is 1.4-fold (0.15 log units) above the measured one; measured number inside the range.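

In this assay, putting ethyl in place of hydrogen on the saturated chain carbon gave a 1.1-fold higher number from compound 3 to compound 4 (0.03 log units; within the scatter). Set beside the earlier step, the change reads alike on the two cores: the same change on two cores in this assay, a 1.8-fold higher number (0.26 log units; within the scatter) from compound 1 to compound 2 and a 1.1-fold higher number (0.03 log units; within the scatter) from compound 3 to compound 4, 1.7-fold (0.23 log units) apart, within the scatter of two such steps. This gives no sign that the change behaves differently on these two cores, but it rests on a single pair for each core, and with both steps inside the scatter it shows neither a real effect of the added ethyl on either core nor any rule for other cores.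

The compounds shown leave open whether a longer chain, or a chain ending in an amine or a carboxylic acid, would move the number beyond the scatter on either core. Also open, going by these compounds, is what the difference between the two cores contributes on its own.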